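Bromo to methoxy on the indoline ring of compound 2

The compounds below may be only part of what the source reports. "The series", "measured", "known", "first", "only" and "open" are said of these compounds alone.

Measured so far:
compound 1 `COC(=O)[C@@]1(C)CCC=C2[C@@H]1CC[C@@H](C)[C@]2(C)Cc1c(C)[nH]c2ccc(Br)cc12` gives 15000 nM in a functional assay on HBL-100 cells (Homo sapiens) for inhibition, read by sulforhodamine B assay, with a stated time of 48 h; a lower number here means a stronger inhibitor of growth, a higher number a weaker inhibitor of growth
compound 2 `COC(=O)[C@@]1(C)CC[C@@H]2C3=C1CC[C@@H](C)[C@]3(C)C[C@@H]1c3cc(Br)ccc3N[C@H]21` gives 34000 nM in this assay

Compound 2 holds the higher of the two numbers, its nearest neighbour being compound 1, which stands beyond the scatter. Compound 3 `COC(=O)[C@@]1(C)CC[C@@H]2C3=C1CC[C@@H](C)[C@]3(C)C[C@@H]1c3cc(OC)ccc3N[C@H]21` carries a methoxy in place of bromo on an aromatic carbon relative to compound 2. For the measured compounds named here, no measured pair shows this swap, so no direction is supported; the step from compound 2 to compound 3 is expected to be small, a 1.1-fold lower number from compound 2 to compound 3 (0.05 log units; within the scatter), within the scatter. Compound 3 is estimated at 30000 nM, with a likely range from 10000 nM to 90000 nM.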

Compound 3, concentration for 50% growth inhibition: 15000 nM
Compound 3: middle estimate off by 2.0-fold (0.30 log units), on the high side; low and high end bracket the measured number.
By their numbers in this assay, from the lowest: compounds 1 and 3 (each within the scatter of the next); then compound 2.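

In this assay, for the compounds shown here, methoxy in place of bromo on an aromatic carbon of the shared core brings a 2.3-fold lower number from compound 2 to compound 3 (0.36 log units; beyond the scatter) as the first reading at this position. The number responds modestly to this swap, and the reading rests on this single pair. Nothing at hand accounts for the step.

As far as these compounds go, whether an amine, a hydroxyl or a longer chain such as ethoxy on this carbon would move the number further remains open. Also open, from the compounds shown here alone, is whether the same swap on the core of compound 1 would give a step of similar size and direction.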